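The compounds below may be only part of what the source reports. "The series", "measured", "known", "first", "only" and "open" are said of these compounds alone.

Compound 1, `CCOC(=O)[C@H](CCC(=O)O)NC(=O)c1ccc(CNc2nc3cc(N)cc(N)c3nc2-c2ccccc2)cc1`: in a functional assay on OVCAR-4 cells (Homo sapiens) for inhibition, read by sulforhodamine B assay, with a stated time of 48 h (on this read-out lower numbers stand for stronger inhibition of growth and higher numbers for weaker inhibition of growth), compound 1 gives 79400 nM.
Compound 2, `Nc1cc(N)c2nc(-c3ccccc3)c(NCc3ccc(Cl)c(Cl)c3)nc2c1`: in this assay compound 2 gives < 100000 nM.

Compound 1 is the only one of the two with a numerical reading in this assay. For compound 2 the result in this assay is a limit of the assay, not a number, so its standing among the measured values is known only as the limit of < 100000 nM in this assay, at which 1 of the 2 values shown sits. Among the measured compounds shown here, no step between measured compounds is available here, and the two values can be said to show only that compound 1 gives a number while compound 2 gives a limit.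

The next compound, compound 3, `COc1ccc(CNc2nc3cc(N)cc(N)c3nc2-c2ccccc2)cc1OC`, is not yet measured in this assay. It differs from compound 2 by 3,4-dimethoxyphenyl in place of 3,4-dichlorophenyl on a saturated chain carbon bound to a nitrogen on an aromatic ring, in words a 3,4-dimethoxyphenyl in place of a 3,4-dichlorophenyl on a saturated chain carbon bound to a nitrogen on an aromatic ring. Since compound 2 is known only as a limit, the size of the step cannot be anchored. For compound 3 a step that the limit leaves unreadable from compound 2 to compound 3 is expected, which is no clearer than the scatter, and compound 3 is estimated at 60000 nM, with a range from 15000 nM to 100000 nM.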

Compound 3, concentration for total growth inhibition: 7410 nM
Estimate against measurement, compound 3: 8.1-fold (0.91 log units) above; the whole stated range lies above it.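

Among the compounds shown here, no step from compound 2 to compound 3 can be read, because compound 2 stands only as a limit of the assay, not as a number: the limit of < 100000 nM in this assay, at which 1 of the 3 values shown sits.

The compounds shown leave open whether, and by how much, 3,4-dimethoxyphenyl in place of 3,4-dichlorophenyl changes the concentration for total growth inhibition in this assay on the shared core.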